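Amide tail replacement on the shared core: compound 4

The compounds below may be only part of what the source reports. "The series", "measured", "known", "first", "only" and "open" are said of these compounds alone.

Measured so far in a functional assay on MCF7 cells (Homo sapiens) for cytotoxicity, read by MTT assay, with a stated time of 24 h; on this read-out lower numbers stand for stronger inhibition and higher numbers for weaker inhibition:
compound 1 `Cn1c(-c2ccc(NC(=O)CSc3nc4cc(Cl)ccc4o3)cc2)nc(-c2ccccc2)c1-c1ccccc1` gives 21.7 ug/mL
compound 2 `Cc1nnc(SCC(=O)Nc2ccc(-c3nc(-c4ccccc4)c(-c4ccccc4)n3C)cc2)s1` gives 3.2 ug/mL
compound 3 `Cn1ccnc1SCC(=O)Nc1ccc(-c2nc(-c3ccccc3)c(-c3ccccc3)n2C)cc1` gives 46.5 ug/mL

Compound 3 carries the highest number of the three. Both measured steps that end at it, a 2.1-fold higher number from compound 1 to compound 3 (0.33 log units; beyond the scatter) and a 15-fold higher number from compound 2 to compound 3 (1.16 log units; beyond the scatter), rise to it, so compound 3 is the weakest of this small set.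

Compound 4 `Cn1c(-c2ccc(NC(=O)CN3CCN(c4ccccc4)CC3)cc2)nc(-c2ccccc2)c1-c1ccccc1` differs from compound 3 by 4-phenylpiperazin-1-yl in place of (1-methyl-1H-imidazol-2-yl)sulfanyl on a saturated chain carbon bound to a carbonyl carbon. All three measured steps, a 6.8-fold lower number from compound 1 to compound 2 (0.83 log units; beyond the scatter), a 2.1-fold higher number from compound 1 to compound 3 (0.33 log units; beyond the scatter) and a 15-fold higher number from compound 2 to compound 3 (1.16 log units; beyond the scatter), exchange one aromatic heterocycle for another while the sulfur stays in place; none removes the sulfur or brings in a saturated ring, so they bear on the new step only by showing that the tail on this chain carbon moves this assay over a modest to large span in either direction. No direction can be drawn from them for the 4-phenylpiperazin-1-yl group.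

The estimate for compound 4 in this assay is therefore centred near the middle of the measured range, 15 ug/mL, with a wide band from 3 ug/mL to 70 ug/mL. This estimate means a step of a 3.1-fold lower number from compound 3 to compound 4 (0.49 log units; beyond the scatter) from compound 3, expected but uncertain in sign.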

Compound 4, half-maximal inhibitory concentration: 10.7 ug/mL
Estimate against measurement, compound 4: 1.4-fold (0.15 log units) above; low and high end bracket the measured number.
By their numbers in this assay, from the lowest: compound 2; then compound 4; then compound 1; then compound 3.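

In this assay the sulfur on the saturated chain carbon bound to a carbonyl carbon is shown to be dispensable for activity, since 4-phenylpiperazin-1-yl, which has no sulfur and brings in a saturated ring, gives a 4.3-fold lower number from compound 3 to compound 4 (0.64 log units; beyond the scatter) and stands as the first tail of this kind in the series. The change has no single direction across the sulfur-linked tails: a 2.0-fold lower number from compound 1 to compound 4 (0.31 log units; beyond the scatter) is also a move to a lower number, whereas a 3.3-fold higher number from compound 2 to compound 4 (0.52 log units; beyond the scatter) goes the other way, so the (5-methyl-1,3,4-thiadiazol-2-yl)sulfanyl tail of compound 2 keeps the lowest number of the four. No measurement is available that accounts for these steps.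

Still open, on these data alone, is whether the saturated ring or the phenyl on it matters more, which a plain piperazine, a morpholine or a piperidine on the same chain carbon would help to separate. Also open, as far as these compounds go, is how a longer chain between the carbonyl and the piperazine would read in this assay, and whether the order of these four tails holds on any other cell line.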